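The source may hold more compounds than are shown below. What is called first, only, known or untested is meant among the compounds shown, and "the series" means these compounds.

In a functional assay on MCF7 cells (Homo sapiens) for antiproliferative activity, read by MTT assay, with a stated time of 48 h (a higher number here means a weaker inhibitor, a lower number a stronger inhibitor), compound 2 `O=C(/C=C/c1ccc(C(F)(F)F)cc1)Nc1nnc(-c2ccc(Br)cc2)s1` gives 1.58 ug/mL, the higher of the two numbers shown so far, though the nearest companion, compound 1 `Cc1ccc(/C=C/C(=O)Nc2nnc(-c3ccc(Br)cc3)s2)cc1`, gives 1.32 ug/mL, and the step of a 1.2-fold higher number from compound 1 to compound 2 (0.08 log units; within the scatter) lies within the scatter. Compound 3 `COc1ccc(-c2nnc(NC(=O)/C=C/c3ccc(C(F)(F)F)cc3)s2)cc1` differs from compound 2 by methoxy in place of bromo on an aromatic carbon. Among the measured compounds shown here, no measured step touches this change: the single step known altered a different group and stayed within the scatter. With nothing to push the expectation either way, compound 3 is estimated at 1.6 ug/mL, with a range from 0.7 ug/mL to 3.6 ug/mL. That estimate means a step of a 1.0-fold higher number from compound 2 to compound 3 (0.01 log units; within the scatter), expected to stay within the scatter.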

Compound 3, half-maximal inhibitory concentration: 0.79 ug/mL
Beside the measured number, compound 3's estimate is 2.0-fold (0.31 log units) above it; the measured number falls inside the stated range.
By their numbers in this assay, from the lowest: compounds 3, 1 and 2 (each within the scatter of the next).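

In this assay, methoxy in place of bromo, para to a large group, gives a 2.0-fold lower number from compound 2 to compound 3 (0.30 log units; within the scatter). Among the compounds shown here, this is the first measured change at this position, since the earlier step altered a different group, and here a hydrogen-bond acceptor that bromo lacks enters without the step leaving the scatter. No measurement shown here bears on this result.

As far as these compounds go, whether an amine or a carboxylic acid at this position would also stay within the scatter remains open. So does whether methoxy would give a similar step alongside the methyl group of compound 1.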